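The source may hold more compounds than are shown below. What is called first, only, known or untested is meant among the compounds shown, and "the series" means these compounds.

Measured in a functional assay on MCF7 cells (Homo sapiens) for cytotoxicity, read by MTT assay, with a stated time of 72 h; on this read-out higher numbers stand for weaker inhibition and lower numbers for stronger inhibition:
- Compound 1 `Nc1cccc(Nc2c(C(=O)NCc3ccc(F)cc3)nc(Br)c3cccnc23)c1`: 8000 nM
- Compound 2 `Nc1ccc(Nc2c(C(=O)NCc3ccc(F)cc3)nc(Br)c3cccnc23)cc1`: 4000 nM
- Compound 3 `N[C@H]1CC[C@H](Nc2c(C(=O)NCc3ccc(F)cc3)nc(Br)c3cccnc23)CC1`: 2000 nM

The standing of compound 3 rests on two steps: a 2.0-fold lower number from compound 2 to compound 3 (0.30 log units; within the scatter) and a 4.0-fold lower number from compound 1 to compound 3 (0.60 log units; beyond the scatter). Compound 4 `NCCNc1c(C(=O)NCc2ccc(F)cc2)nc(Br)c2cccnc12` differs from compound 3 in one place, with 2-aminoethyl in place of 4-aminocyclohexyl on a nitrogen on an aromatic ring. The measured swaps at this nitrogen are those two steps and a 2.0-fold lower number from compound 1 to compound 2 (0.30 log units; within the scatter), and only a 4.0-fold lower number from compound 1 to compound 3 (0.60 log units; beyond the scatter) passes the scatter. No open chain has been measured there, so the direction remains uncertain. In this assay no step beyond the scatter is expected, and the estimated step is a 1.5-fold higher number from compound 3 to compound 4 (0.18 log units; within the scatter). For compound 4 the estimated value is 3000 nM, with an expected range of 1000 nM to 10000 nM.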

Compound 4, half-maximal inhibitory concentration: 6000 nM
Compound 4: middle estimate off by 2.0-fold (0.30 log units), on the low side; the range from low to high includes it.
By their numbers in this assay, from the lowest: compounds 3, 2, 4 and 1 (each within the scatter of the next, the first and the last beyond it).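

In this assay, going by these compounds alone, the 2-aminoethyl chain is the first group without a ring at this nitrogen, and a 3.0-fold higher number from compound 3 to compound 4 (0.48 log units; beyond the scatter) shows that replacing 4-aminocyclohexyl with this chain can matter. The chain cannot be told apart from the two aminophenyl groups, with a 1.5-fold higher number from compound 2 to compound 4 (0.18 log units; within the scatter) and a 1.3-fold lower number from compound 1 to compound 4 (0.12 log units; within the scatter) as the steps. A ring at this nitrogen therefore does not by itself give a lower number, and nothing shown accounts for these differences. On these data alone, whether a longer chain with a terminal amine would come closer to compound 3 remains open, as does whether a chain with no amine or with a carboxylic acid would keep this level.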